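Tetrazole acetamides: from compound 3 to compound 4

This account rests on a few compounds, and the source may have more. Where it says the series, first, only, none or still open, it means among the compounds named here.

Among the measured compounds shown here, compound 3 `Cc1cc(NC(=O)Cn2nnc(-c3cc(Cl)cc(Cl)c3)n2)n(C2CCCCC2)n1` carries the only plain number in an assay on HEK293 cells for activation of Kir3.1/Kir3.2 (Homo sapiens), read by thallium flux (on this read-out higher numbers stand for larger maximal responses and lower numbers for smaller maximal responses), where compound 3 reaches 82%. Compound 1 `Cc1cc(NC(=O)Cn2nnc(-c3ccccc3)n2)n(C2CCS(=O)(=O)CC2)n1` is reported in this assay only as a limit, namely > 25%, which is a bound of the measurement and not a number. Compound 2 `Cc1nc(-c2ccccc2)c(NC(=O)Cn2nnc(-c3ccccc3)n2)s1`, built on another core, is recorded in this assay as "not active" (no number reported). For the measured compounds named here, no pair of measured compounds differing in one place exists in this set, so the only footing for compound 4 `Cc1cc(NC(=O)Cn2nnc(-c3cccc(C#N)c3)n2)n(C2CCCCC2)n1` is the reading of compound 3 together with the change itself. The change from compound 3 to compound 4 is 3-cyanophenyl in place of 3,5-dichlorophenyl on an aromatic carbon. Going by the values given here, the set gives no measured step of this kind. A moderate fall in this assay is expected, somewhat beyond the usual scatter, while compound 4 should still show a clear response. For compound 4 the largest response in this assay is estimated at 60%, between 30% and 90%. That estimate corresponds to a number 22 percentage points lower from compound 3 to compound 4 (beyond the scatter).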

Compound 4, largest response reached (Emax), in percent of the reference or control that the assay uses: 80%
Estimate against measurement, compound 4: 20 percentage points below; measured number inside the range.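

In this assay, among the compounds shown here, the first measured step, a number 2 percentage points lower from compound 3 to compound 4 (within the scatter), shows that this aromatic carbon accepts a change of substituent with no separation between the two readings. A large response on the shared core therefore does not depend on 3,5-dichlorophenyl: 3-cyanophenyl, which has no chlorine and brings a triple bond and a hydrogen-bond acceptor, gives a reading that cannot be told apart from it. Nothing at hand bears on the cause of this result.

Still open, going by these compounds, is how a phenyl ring carrying an amine or a carboxylic acid would read at this place, with the rest of compound 3 unchanged. Compound 1, the closest reference with plain phenyl, has only a limit of > 25%, which is not a number, and it differs from compound 3 in more than one place.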